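Swapping the aryl group on a shared pyridine-free core

The source may hold more compounds than are shown below. What is called first, only, known or untested is meant among the compounds shown, and "the series" means these compounds.

Compound 3 `Cc1ccccc1-c1cc(-c2ccoc2)cc(-c2ccc(Cl)s2)n1` was measured in an assay on isolated protein for inhibition of DNA topoisomerase 1 (Homo sapiens), with a stated time of 30 min, tested at 100 uM (on this read-out lower numbers stand for less inhibition and higher numbers for more inhibition at the one concentration tested (going by the name of the read-out)), where compound 3 gives 4.6%. Compound 1 `Cc1ccsc1-c1cc(-c2ccco2)cc(-c2ccccc2Cl)n1` gives 2% and compound 2 `Cc1ccsc1-c1cc(-c2ccco2)cc(-c2ccc(Cl)cc2)n1` gives 1%; all three numbers lie within the scatter of one another, so compound 3 stands apart from neither. Going by the values given here, the only measured single change, a number 1 percentage points lower from compound 1 to compound 2 (within the scatter), concerns a chlorophenyl group and stays within the scatter. Compound 4 `Clc1ccc(-c2cc(-c3ccoc3)cc(-c3ccc(Cl)s3)n2)cc1` differs from compound 3 by 4-chlorophenyl in place of 2-methylphenyl on an aromatic carbon. Among the compounds with values here, no measured step matches this exchange directly, and the one related step gives no movement beyond the scatter, so compound 4 is expected to show a number 1.6 percentage points lower from compound 3 to compound 4 (within the scatter). The estimate for compound 4 is therefore 3%, from 0% to 12%.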

Compound 4, a percentage reported as inhibition, at one concentration (the size of the read-out at that concentration, not a potency): 2.3%
Compound 4: the middle estimate sits 0.7 percentage points above what was measured; measured number inside the range.
By their numbers in this assay, from the lowest: compounds 2, 1, 4 and 3 (each within the scatter of the next).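

In this assay the exchange of 2-methylphenyl for 4-chlorophenyl next to the ring nitrogen gives a number 2.3 percentage points lower from compound 3 to compound 4 (within the scatter) and is the first step shown at this position. On this core, with its furan-3-yl and 5-chlorothiophen-2-yl groups, the read-out does not separate these two aryl groups. Nothing measured bears on why this step stays within the scatter.

On these data alone, whether an amine or a carboxylic acid at this position would move the number beyond the scatter remains open. So does whether the same exchange would behave alike on the core of compound 1.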